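The source may report more compounds than this note shows. Statements on the series, on what has been measured and on what is new or still open speak of the compounds shown alone.

Measured so far in this series:

compound 1, `O=C(CCCc1ccccc1)Nc1nc2ccccc2c(=O)s1`: 229 nM
compound 2, `O=C(CCCc1ccc(Cl)c(Cl)c1)Nc1nc2ccccc2c(=O)s1`: > 1500 nM

In an assay on membranes from brain for displacement of a labelled ligand from adenosine receptor A1 (Rattus norvegicus), read by scintillation counting, with a stated time of 90 min (on this read-out higher numbers stand for weaker inhibition and lower numbers for stronger inhibition), compound 1 gives 229 nM. For compound 2 this assay reports only a limit, > 1500 nM, which is the line (the limit of > 1500 nM in this assay, at which 1 of the 2 values shown sits); compound 2 therefore stands without a firm number, and only the edge of the measurable range is known for it. Among the compounds with values here, the single measured step, an at least 6.5-fold higher number from compound 1 to compound 2 (0.81 log units; beyond the scatter), is the only one that touches the same place on the chain, and it ran toward weaker inhibition.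

Compound 3 is `COc1cccc(CCCC(=O)Nc2nc3ccccc3c(=O)s2)c1`. It differs from compound 2 as follows: 3-methoxyphenyl in place of 3,4-dichlorophenyl on a saturated chain carbon, three bonds along the chain from a carbonyl carbon. Within the data shown here, this change takes away the 3,4-dichlorophenyl that, in the step from compound 1 to compound 2, went with a higher number, but it does not restore the plain phenyl of compound 1; no measured step covers a methoxy group at this place.

Among the measured compounds shown here, because an at least 6.5-fold higher number from compound 1 to compound 2 (0.81 log units; beyond the scatter) was the only step beyond the scatter and points away from the 3,4-dichlorophenyl, the estimated step of an at least 2.5-fold lower number from compound 2 to compound 3 (0.39 log units; beyond the scatter) is expected to run toward a lower number, though its size is uncertain. Compound 3 is expected to give 600 nM, with a range from 200 nM to 2000 nM.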

Compound 3, inhibition constant: 22.5 nM
Compound 3: the middle estimate sits 27-fold (1.43 log units) above what was measured; measured number below the stated range.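

Within the data shown here, until now, the only change on this aromatic ring had gone toward weaker inhibition. With the methoxy group in place of hydrogen on an aromatic carbon, a 10-fold lower number from compound 1 to compound 3 (1.01 log units; beyond the scatter), the same ring now also shows a change toward stronger inhibition than the plain phenyl gives, so a substituent here can move the result in either direction. Replacing the 3,4-dichlorophenyl with the 3-methoxyphenyl, two groups with the same count of heavy atoms, gives an at least 66-fold lower number from compound 2 to compound 3 (1.82 log units; beyond the scatter), which shows that the kind of substituent matters here and not just the size of the group as counted in heavy atoms; the value for compound 2 in that step is a limit and not a number: the limit of > 1500 nM in this assay, at which 1 of the 3 values shown sits.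

On these data alone, what stays open is whether the stronger inhibition belongs to the methoxy group itself, with its oxygen, or would also appear with a hydroxy group, an ethoxy group or a single chlorine on the same ring. The compounds shown also leave open how the 3-methoxyphenyl would behave on a longer chain, and whether the gain would carry over to other groups at the end of it, such as an amine.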